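A Thioester Series Tested for Cytotoxicity in Mouse Macrophages

A few compounds are considered here, and "the series" means these few. Any claim that something is new, unique, unknown or untested is made for them only; others in the source may bear on it.

Three closely related compounds were tested for cytotoxicity in an ADME assay on RAW264.7 cells (Mus musculus) for cytotoxicity, read by MTT assay, with a stated time of 24 h; on this read-out higher numbers stand for weaker inhibition and lower numbers for stronger inhibition. Compound 1, with the structure `O=C(S[C@@]12CC[C@H](O)[C@@H]1C(=O)NC2=O)c1ccc(O)cc1`, gives 1020000 nM. Compound 2, drawn as `O=C(SC12CCC(O)C1C(=O)NC2=O)c1ccc(O)cc1`, gives 434000 nM, and compound 3, drawn as `O=C(S[C@]12CC[C@H](O)[C@H]1C(=O)NC2=O)c1ccc(O)cc1`, gives 1380000 nM. Among these three numbers compound 1 stands second highest: its nearest neighbour is compound 3, separated by a 1.4-fold higher number from compound 1 to compound 3 (0.13 log units; within the scatter), and its furthest is compound 2, separated by a 2.4-fold lower number from compound 1 to compound 2 (0.37 log units; beyond the scatter). Between compound 2 and compound 3 the gap is a 3.2-fold higher number from compound 2 to compound 3 (0.50 log units; beyond the scatter). All three compounds share the same atoms and bonds; they differ only in how the stereocentres are drawn, as the fact that one of compounds 1 and 2 is drawn with a defined configuration and the other without, at the place where they differ, the fact that compounds 1 and 3 differ only in the configuration as drawn and the fact that one of compounds 2 and 3 is drawn with a defined configuration and the other without, at the place where they differ show.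

The compound now to be considered is compound 4, with the structure `O=C(S[C@@]12CC[C@H](O)[C@@H]1C(=O)NC2=O)c1ccccc1`. It differs from compound 1 by hydrogen in place of hydroxy on an aromatic carbon. Among the compounds with values here, none of the measured steps touches this part of the molecule, since each of them concerns only the drawing of stereocentres on saturated ring carbons. The measured steps therefore give no guide to the size or direction of this change, and no step beyond the usual scatter is expected in this assay. Compound 4 is expected to give about 1000000 nM, within a range from 400000 nM to 2500000 nM, which means an estimated step of a 1.0-fold lower number from compound 1 to compound 4 (0.01 log units; within the scatter).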

Compound 4, half-maximal inhibitory concentration: 479000 nM
Compound 4: middle estimate off by 2.1-fold (0.32 log units), on the high side; the measured number falls inside the stated range.
By their numbers in this assay, from the lowest: compounds 2 and 4 (each within the scatter of the next); then compounds 1 and 3 (each within the scatter of the next).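

Taking the hydroxy off the aromatic ring is the first change here that reaches beyond the drawing of the stereocentres, and in this assay it gives a 2.1-fold lower number from compound 1 to compound 4 (0.33 log units; beyond the scatter), a modest step but one beyond the usual scatter. On this read-out a lower number means stronger inhibition, so the change from 4-hydroxyphenyl to phenyl moves the result towards greater cytotoxicity, which shows that this aromatic position, para to a large group, can shift the result in this assay and is not just a passive part of the molecule. The available observations concern only how the stereocentres are drawn, so none of them offers an explanation for this step.

A single replacement cannot show whether the result depends on the hydroxy specifically or on the position more generally, and a methoxy group, an amine or a fluorine atom at the same place on the ring would help to separate those possibilities. On these data alone, it also remains open whether the same change would give a similar step in the configurations drawn in compound 2 and compound 3.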